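Chloro to hydroxy: from compound 3 to compound 4

A few compounds are considered here, and "the series" means these few. Any claim that something is new, unique, unknown or untested is made for them only; others in the source may bear on it.

Measured so far in an assay on brain for binding affinity to Neuronal acetylcholine receptor; alpha4/beta2 (Rattus norvegicus), read by radioligand binding; on this read-out lower numbers stand for stronger inhibition and higher numbers for weaker inhibition:
compound 1 `Cc1ccc(OC[C@@H]2CCN2)cn1`: 0.057 nM
compound 2 `Clc1cncc(OC[C@@H]2CCN2)c1`: 0.042 nM
compound 3 `Clc1cncc(OC[C@H]2CCN2)c1`: 0.12 nM

Compound 3 stands highest of the three numbers; compound 1 lies nearer to it, compound 2 furthest. Among the measured compounds shown here, the only step between neighbours, a 2.9-fold higher number from compound 2 to compound 3 (0.46 log units; beyond the scatter), rests on the fact that compounds 2 and 3 differ only in the configuration as drawn and concerns configuration alone.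

Compound 4 `Oc1cncc(OC[C@H]2CCN2)c1` differs from compound 3 by hydroxy in place of chloro on an aromatic carbon. For the measured compounds named here, compound 4 keeps the configuration drawn in compound 3, so the measured step does not bear on it, and no measured pair shows a hydroxy in place of a chloro. The scale is set by compound 3 only. A modest move towards a higher number, beyond the scatter, seems the likelier outcome.

Compound 4 is expected in this assay at 0.3 nM, range 0.06 nM to 1.5 nM. This estimate means a step of a 2.5-fold higher number from compound 3 to compound 4 (0.40 log units; beyond the scatter).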

Compound 4, inhibition constant: 0.088 nM
Estimate against measurement, compound 4: 3.4-fold (0.53 log units) above; the measured number falls inside the stated range.
By their numbers in this assay, from the lowest: compounds 2, 1, 4 and 3 (each within the scatter of the next, the first and the last beyond it).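

In this assay hydroxy in place of chloro gives a 1.4-fold lower number from compound 3 to compound 4 (0.13 log units; within the scatter) at this position, on an aromatic carbon two atoms from the ring nitrogen. With the configuration drawn in compound 3, this position therefore takes a hydrogen-bond donor and acceptor in place of chloro without a shift beyond the scatter. No measured property available here bears on this step.

As far as these compounds go, whether hydroxy behaves the same way in the configuration drawn in compound 2 remains open. From the compounds shown here alone, how an amine or a carboxylic acid would read at this position also remains open.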